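Adenosine-like nucleosides: benzylamine swap on compound 1

The source may hold more compounds than are shown below. What is called first, only, known or untested is meant among the compounds shown, and "the series" means these compounds.

Measured compounds:
- compound 1 `OC[C@H]1O[C@@H](n2cnc3c(NCc4ccc(Cl)cc4Cl)ncnc32)[C@H](O)[C@@H]1O`: 86700 nM
- compound 2 `COc1cc(O)cc(OC)c1CNc1ncnc2c1ncn2[C@@H]1O[C@H](CO)[C@@H](O)[C@H]1O`: "not determined" (no result reported)

For the measured compounds named here, compound 1 is the only compound of this pair with a number; in a functional assay on CCRF-CEM cells (Homo sapiens) for antiproliferative activity, with a stated time of 72 h (on this read-out lower numbers stand for stronger inhibition and higher numbers for weaker inhibition), compound 1 gives 86700 nM, a weak inhibition. Compound 2 is the second compound of the series, a benzyl-substituted analogue sharing the same core, but in this assay compound 2 gives "not determined" (no result reported), so it gives no guide to the size of any step.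

Compound 3 `Cc1ccc(O)c(CNc2ncnc3c2ncn3[C@@H]2O[C@H](CO)[C@@H](O)[C@H]2O)c1` is not yet measured. It differs from compound 1 in one place: 2-hydroxy-5-methylphenyl in place of 2,4-dichlorophenyl on a saturated chain carbon bound to a nitrogen on an aromatic ring. The two groups hold the same number of heavy atoms and each carries one six-membered aromatic carbon ring, the difference being the two chlorines giving way to a hydroxyl and a methyl.

Going by the values given here, with no step among measured compounds to lean on, the expectation is that the change from compound 1 to compound 3 stays close to the scatter; the estimated step is a 1.2-fold higher number from compound 1 to compound 3 (0.06 log units; within the scatter) in this assay. On that basis compound 3 is expected to give 100000 nM, within a range from 30000 nM to 300000 nM.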

Compound 3, half-maximal inhibitory concentration: 1900 nM
Compound 3: middle estimate off by 53-fold (1.72 log units), on the high side; measured number outside the range, below it.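

In this assay the group on a saturated chain carbon bound to a nitrogen on an aromatic ring proves able to move the read-out strongly: 2-hydroxy-5-methylphenyl in place of 2,4-dichlorophenyl gives a 46-fold lower number from compound 1 to compound 3 (1.66 log units; beyond the scatter) even though both groups hold the same number of heavy atoms and one six-membered aromatic carbon ring. For the compounds shown here, the earlier compounds offered no step at all, so this is the first sign that the shared core does not alone set the level in this assay and that the substituents on this ring count. No measurement at hand bears on why the step has this size, and this single step cannot separate the entry of the hydroxyl, the entry of the methyl and the loss of the two chlorines.

The step from compound 1 to compound 2 cannot be read, as compound 2 has no number, so a second substitution pattern gives no check on this result. Still open, as far as these compounds go, is which part of the change carries the step, and whether an amine or a carboxylic acid in place of the hydroxyl would hold the level of compound 3.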